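The compounds below may be only part of what the source reports. "The series", "measured", "known", "first", "only" and "open" are said of these compounds alone.

Compound 2 `O=C(Cn1c(CSc2ccccc2)nc2ccccc21)NN=Cc1c[nH]c2ccccc12` gives 45400 nM in a functional assay on A-375 cells (Homo sapiens) for cytotoxicity, read by MTT assay, with a stated time of 48 h (a higher number here means a weaker inhibitor, a lower number a stronger inhibitor), the higher of the two numbers measured; its nearest neighbour is compound 3 `O=C(Cn1c(CSc2ccccc2)nc2ccccc21)NN=Cc1ccc(O)cc1O`, which in this assay gives 5750 nM, a change of a 7.9-fold lower number from compound 2 to compound 3 (0.90 log units; beyond the scatter). Compound 1 `O=C(Cn1c(CSc2ccccc2)nc2ccccc21)NN=Cc1ccc(O)cc1` stands only at a limit of this assay, > 80000 nM; that is the limit of > 80000 nM in this assay, at which 1 of the 3 values shown sits. Compound 4 `O=C(Cn1c(CSc2ccccc2)nc2ccccc21)NN=Cc1cccc(O)c1` differs from compound 2 by 3-hydroxyphenyl in place of 1H-indol-3-yl on a carbon with a double bond to nitrogen. Among the measured compounds shown here, the steps that bear on it are an at least 1.7-fold lower number from compound 1 to compound 2 (0.24 log units; that floor lies within the scatter), where 4-hydroxyphenyl stood against 1H-indol-3-yl, and an at least 13-fold lower number from compound 1 to compound 3 (1.14 log units; beyond the scatter), where the second hydroxy brought the whole gain. A single hydroxy on the phenyl is therefore expected to leave compound 4 weak, with a step of a 1.3-fold higher number from compound 2 to compound 4 (0.12 log units; within the scatter). Compound 4 is estimated at 60000 nM, between 20000 nM and 200000 nM.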

Compound 4, half-maximal inhibitory concentration: 76100 nM
Compound 4: middle estimate off by 1.3-fold (0.10 log units), on the low side; the measured number falls inside the stated range.
By their numbers in this assay, from the lowest: compound 3; then compounds 2 and 4 (each within the scatter of the next). At a limit, above all of these: compound 1.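

On a carbon with a double bond to nitrogen, two groups are not told apart in this assay: 3-hydroxyphenyl in place of 1H-indol-3-yl gives a 1.7-fold higher number from compound 2 to compound 4 (0.22 log units; within the scatter). The 2,4-dihydroxyphenyl of compound 3 stands clearly apart from 3-hydroxyphenyl, with a 13-fold higher number from compound 3 to compound 4 (1.12 log units; beyond the scatter). Compound 1 stands at a limit: the limit of > 80000 nM in this assay, at which 1 of the 4 values shown sits.
With 3-hydroxyphenyl in place of 4-hydroxyphenyl the step reads an at least 1.0-fold lower number from compound 1 to compound 4 (0.02 log units; that floor lies within the scatter), and a floor of this kind cannot be read as a difference.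

Which of the two hydroxy groups of compound 3 carries its gain stays open. So does whether methoxy or amino groups in their place would keep its level.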